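The compounds below may be only part of what the source reports. "The series", "measured", "known", "first", "only" and "open" are said of these compounds alone.

Measured compounds:
- compound 1, `Cc1ccc(C(=O)Nc2cc(-c3cnn(C)c3)cc(C(F)(F)F)c2)cc1Nc1cc(-c2cccnc2)ccn1`, in a toxicity assay on L02 cells (Homo sapiens) for cytotoxicity, read by MTT assay, with a stated time of 48 h; a higher number here means a weaker inhibitor, a lower number a stronger inhibitor: > 80000 nM
- compound 2, `Cc1ccc(C(=O)Nc2ccc(CN3CCN(C)CC3)c(C(F)(F)F)c2)cc1Nc1cc(-c2cccnc2)ccn1`, in this assay: compound 2 gives 37400 nM.

Within the data shown here, compound 1 has the reading > 80000 nM, which is a limit of this assay and not a number, the only such reading among the two, as recorded in the limit of > 80000 nM in this assay, at which 1 of the 2 values shown sits. Compound 2 therefore holds the only number shown in this assay, and no step between two measured compounds is available, so nothing can yet be set against the scatter.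

Compound 3, `Cc1ccc(C(=O)Nc2ccc(CN3CCN(C)CC3)c(C(F)(F)F)c2)cc1Nc1cc(-c2cncnc2)ccn1`, has not been measured. It departs from compound 2 by pyrimidin-5-yl in place of pyridin-3-yl on an aromatic carbon; cut one bond further out, 4-(pyridin-3-yl)pyridin-2-yl becomes 4-(pyrimidin-5-yl)pyridin-2-yl, with the rest of compound 2 unchanged.

Among the measured compounds shown here, with no measured step to draw on, the step from compound 2 to compound 3 in this assay is expected to be small, in no fixed direction, amounting to a 1.1-fold higher number from compound 2 to compound 3 (0.03 log units; within the scatter) and staying within the scatter. Compound 3 is accordingly estimated at 40000 nM in this assay, with a range from 15000 nM to 100000 nM. A reading that comes out as a limit of this assay would not be surprising.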

Compound 3, half-maximal inhibitory concentration: 30100 nM
Compound 3: middle estimate off by 1.3-fold (0.12 log units), on the high side, and the stated range covers the measured number.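

In this assay the series now has its first readable step: a 1.2-fold lower number from compound 2 to compound 3 (0.09 log units; within the scatter). At this place, on an aromatic carbon of the six-membered ring and opposite the ring nitrogen, pyridin-3-yl and pyrimidin-5-yl give readings that cannot be told apart, so an added ring nitrogen in this outer ring, with one more hydrogen-bond acceptor counted, brings no change beyond the scatter on the background of compound 2. Nothing at hand gives a cause for the size of this step.

As far as these compounds go, only these two rings can be compared at this place, so it remains open whether phenyl, pyridin-4-yl, or a ring carrying an amine or a carboxylic acid would also stay within the scatter in this assay. Also open, from the compounds shown here alone, is whether the same exchange would behave alike on compound 1, whose reading of > 80000 nM is a limit and not a number.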